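Solubility notes on a benzyl to trifluoromethyl exchange

The source may hold more compounds than are shown below. What is called first, only, known or untested is meant among the compounds shown, and "the series" means these compounds.

Measured compounds:
compound 1 `O=[N+]([O-])c1cn2c(n1)OC[C@@H](OCCOc1ccc(OCc3ccccc3)cc1)C2`: 1.7 ug/mL
compound 2 `O=[N+]([O-])c1cn2c(n1)OC[C@@H](OC/C=C/c1ccc(OC(F)(F)F)cc1)C2`: 1.5 ug/mL
compound 3 `O=[N+]([O-])c1cn2c(n1)OC[C@@H](OC/C=C/c1ccc(OCc3ccccc3)cc1)C2`: 0.06 ug/mL

In a physicochemical assay for solubility, read by HPLC, at pH 7 (on this read-out higher numbers stand for higher solubility and lower numbers for lower solubility), compound 1 gives 1.7 ug/mL, compound 2 gives 1.5 ug/mL and compound 3 gives 0.06 ug/mL. Compound 1 and compound 2 lie within the scatter of each other, so no order is drawn between them. Compound 3 sits far below both.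

One structural change appears twice in this set. Between compound 3 and compound 2 it reads trifluoromethyl in place of benzyl on an oxygen on an aromatic ring and it produced a 25-fold higher number from compound 3 to compound 2 (1.40 log units; beyond the scatter). The same change, word for word at the same place, leads from compound 1 to the unmeasured compound 4 `O=[N+]([O-])c1cn2c(n1)OC[C@@H](OCCOc1ccc(OC(F)(F)F)cc1)C2`: trifluoromethyl in place of benzyl on an oxygen on an aromatic ring. The difference between the core of compound 1 and the core of compound 3 is not broken down here.

For compound 4 the step is expected to go in the same direction as a 25-fold higher number from compound 3 to compound 2 (1.40 log units; beyond the scatter), but a smaller one is expected, a 5.9-fold higher number from compound 1 to compound 4 (0.77 log units; beyond the scatter), because compound 1 already starts at 1.7 ug/mL, well above compound 3, and the change was measured only once, on a core that is not the core of compound 1. In this assay compound 4 is estimated at 10 ug/mL, with a likely range from 3 ug/mL to 40 ug/mL.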

Compound 4, solubility: 50 ug/mL
Beside the measured number, compound 4's estimate is 5.0-fold (0.70 log units) below it; the whole stated range lies below it.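

Trifluoromethyl in place of benzyl on an oxygen on an aromatic ring has now been read on two cores in this assay, and both pairs move the same way: a 25-fold higher number from compound 3 to compound 2 (1.40 log units; beyond the scatter) and a 29-fold higher number from compound 1 to compound 4 (1.47 log units; beyond the scatter). Within this series, then, the direction and the large size of the step carried over from one core to the other, even though the core of compound 1 and the core of compound 3 are not the same, so the exchange can be treated as transferable across these two cores, with one matched pair on each. This does not show that the step would hold on any further core, and nothing shown bears on why it is so large on both.

Still open, as far as these compounds go, is whether other groups in the same place, on an oxygen on an aromatic ring, such as a methyl, a longer chain or a chain ending in an amine or a carboxylic acid, would give a step of similar direction and size in this assay. The compounds shown also leave open how the step would read on a core outside this pair, and whether it would reach any read-out other than this one.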